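The source may report more compounds than this note shows. Statements on the series, on what has been measured and on what is new or still open speak of the compounds shown alone.

Compound 1, with the structure `Fc1ccccc1Cc1nc(-c2nc(C(F)F)n[nH]2)n2ccccc12`, is one of two compounds that have been tested in an ADME assay on MDCKII-LE cells (Canis lupus familiaris) for permeability, in the apical to basolateral direction; on this read-out lower numbers stand for lower permeability and higher numbers for higher permeability. In this assay compound 1 gives 0.2 10^-6 cm/s, the lowest of the two numbers that have been measured. The other measured compound is compound 2, with the structure `Fc1ccccc1Cc1nc(-c2nc(C(F)(F)F)n[nH]2)c2ccccn12`; in this assay compound 2 gives 17 10^-6 cm/s, which is far above the number for compound 1 and well beyond the usual scatter of the assay. Compound 2 differs from compound 1 both in its core and in the group on the five-membered ring, so the gap between the two cannot be assigned to either change on its own.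

Compound 3, with the structure `Fc1ccccc1Cc1nc(-c2nc(C(F)(F)F)n[nH]2)n2ccccc12`, keeps the core of compound 1 and carries the change (fluoro in place of hydrogen on a saturated chain carbon bound to an aromatic carbon and two fluorine atoms). Within the data shown here, no step between measured compounds that share this single change is available, so the expectation rests on the numbers for compound 1 and compound 2 alone. The step from compound 1 to compound 3 is expected to be upward, of the size a 7.5-fold higher number from compound 1 to compound 3 (0.88 log units; beyond the scatter), which lies beyond the scatter. For compound 3 the estimated value in this assay is 1.5 10^-6 cm/s, with a range from 0.3 10^-6 cm/s to 8 10^-6 cm/s.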

Compound 3, apparent permeability: 6 10^-6 cm/s
Beside the measured number, compound 3's estimate is 4.0-fold (0.60 log units) below it; the measured number falls inside the stated range.
By their numbers in this assay, from the lowest: compound 1; then compound 3; then compound 2.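

In this assay, exchanging difluoromethyl for trifluoromethyl while the core of compound 1 stays the same gives a 30-fold higher number from compound 1 to compound 3 (1.48 log units; beyond the scatter) and this large step lies beyond the scatter. A single fluoro in place of hydrogen, on a saturated chain carbon bound to an aromatic carbon and two fluorine atoms, is therefore enough on its own to move this read-out strongly, something that compound 1 and compound 2 could not show, since they differ in both the core and the group on the five-membered ring. Nothing measured here gives the reason for a step of this size.

The compounds shown leave open whether the same exchange would have a comparable effect on the core of compound 2, where only the trifluoromethyl form appears. Among these compounds, they also leave open how the read-out would respond at this position to a plain methyl group, a single chlorine atom or a longer chain such as pentafluoroethyl, so the step describes only this one exchange on this one core.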